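A Thioether Swap on a Weakly Growth-Inhibiting Core

The source may report more compounds than this note shows. Statements on the series, on what has been measured and on what is new or still open speak of the compounds shown alone.

Compound 1 `Nc1cc(N)c2nc(-c3ccccc3)c(Oc3ccc(Cl)c(Cl)c3)nc2c1` gives 20400 nM in a functional assay on COLO 205 cells (Homo sapiens) for inhibition, read by sulforhodamine B assay, with a stated time of 48 h; a higher number here means a weaker inhibitor of growth, a lower number a stronger inhibitor of growth. Compound 2 `CCOC(=O)[C@H](CCC(=O)O)NC(=O)c1ccc(CNc2nc3cc(N)cc(N)c3nc2-c2ccccc2)cc1` gives 19500 nM in this assay, and compound 3 `CCOC(=O)[C@H](CCC(=O)O)NC(=O)c1ccc(Sc2nc3cc(N)cc(N)c3nc2-c2ccccc2)cc1` gives 28200 nM; all three numbers lie within the scatter of one another, so compound 1 stands alongside the other two rather than apart from them. Compound 4 `Nc1cc(N)c2nc(-c3ccccc3)c(Sc3ccc(F)cc3)nc2c1` differs from compound 1 by (4-fluorophenyl)sulfanyl in place of 3,4-dichlorophenoxy on an aromatic carbon. For the measured compounds named here, no measured pair shows this change directly, and the three known values are close, so no step beyond the scatter is expected in either direction. Compound 4 is therefore expected to give about 22000 nM in this assay, within a range from 8000 nM to 60000 nM, which means an expected step of a 1.1-fold higher number from compound 1 to compound 4 (0.03 log units; within the scatter).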

Compound 4, concentration for 50% growth inhibition: 21900 nM
Estimate against measurement, compound 4: 1.0-fold (0.00 log units) above, within the range that was stated.
By their numbers in this assay, from the lowest: compounds 2, 1, 4 and 3 (each within the scatter of the next).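

Placing (4-fluorophenyl)sulfanyl in place of 3,4-dichlorophenoxy on the aromatic carbon next to the ring nitrogen gives, in this assay, a 1.1-fold higher number from compound 1 to compound 4 (0.03 log units; within the scatter). This position therefore accepts a change of both the linking atom and the halogens on the outer ring with no step beyond the scatter. Nothing measured here bears on the reason for this result.

As far as these compounds go, whether the sulfur or the halogens alone would matter stays open, since both change together. So does the effect of a smaller group here, such as an amine or a carboxylic acid.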